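Amide nitrogen substituent in a thienylmethyl aryloxyacetamide pair

The source may hold more compounds than are shown below. What is called first, only, known or untested is meant among the compounds shown, and "the series" means these compounds.

Two compounds of the series have numbers in an assay on HEK293 cells for agonist activity at transient receptor potential cation channel subfamily M member 8 (Homo sapiens), read by fluorescence and calcium flux, with a stated time of 15 min; on this read-out higher numbers stand for an effect only at larger amounts of compound and lower numbers for an effect already at smaller amounts. Compound 1 `CCCc1ccc(OCC(=O)N(CC)Cc2cccs2)cc1` gives 1810 nM in this assay. Going by the values given here, compound 2 `CON(Cc1cccs1)C(=O)COc1ccc(C)cc1` gives 10 nM in this assay, the lowest of the two numbers, with compound 1 the nearest and beyond the scatter; the two differ in more than one place, so only the pair of values is known. Compound 3 `CCCN(Cc1cccs1)C(=O)COc1ccc(C)cc1` has not been measured. Its change from compound 2 is propyl in place of methoxy on an amide-type nitrogen. Among the compounds with values here, no measured step of this kind exists, so the expectation rests on compound 2 alone; a moderate rise in the number is expected, a 6.0-fold higher number from compound 2 to compound 3 (0.78 log units; beyond the scatter). Compound 3 is estimated at 60 nM, in the range 15 nM to 300 nM.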

Compound 3, half-maximal effective concentration: 40 nM
Compound 3: the middle estimate sits 1.5-fold (0.18 log units) above what was measured; the measured number falls inside the stated range.
By their numbers in this assay, from the lowest: compound 2; then compound 3; then compound 1.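

In this assay, propyl in place of methoxy on an amide-type nitrogen gives only a modest change, a 4.0-fold higher number from compound 2 to compound 3 (0.60 log units; beyond the scatter). Going by these compounds alone, this is the first reading of a single change at this position, and it shows that the low number of compound 2 does not depend wholly on methoxy: compound 3 stays at 40 nM. No evidence bearing on the size of this step is at hand. Still open, as far as these compounds go, is how a longer chain such as hexyl, a hydroxyl-ended chain or an amine on this nitrogen would read.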